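The compounds below may be only part of what the source reports. "The series", "measured", "known", "first", "only" and "open" are said of these compounds alone.

Working notes on the series in a functional assay on HT-29 cells (Homo sapiens) for cytotoxicity, read by sulforhodamine B assay; a higher number here means that more compound is tolerated, a lower number that less compound is tolerated. Compound 1 `CC1=CC[C@@H]([C@@](C)(O)CCCC(C)(C)NC(=S)NN)CC1` gives > 100000 nM, which is a limit and not a number. Compound 2 `CC1=CC[C@@H]([C@@](C)(O)CCCC(C)(C)NC(=S)N/N=C\c2cccc([N+](=O)[O-])c2)CC1`, carrying 3-nitrophenyl, gives > 100000 nM, again a limit. Compound 3 `CC1=CC[C@@H]([C@@](C)(O)CCCC(C)(C)NC(=S)N/N=C\c2ccc([N+](=O)[O-])cc2)CC1`, carrying 4-nitrophenyl, gives > 100000 nM, also a limit. Compound 3 therefore has no number of its own and stands with the other two compounds: the limit of > 100000 nM in this assay, at which 3 of the 3 values shown sit.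

The move to compound 4 `CC1=CC[C@@H]([C@@](C)(O)CCCC(C)(C)NC(=S)N/N=C\c2cccc(Cl)c2)CC1` is 3-chlorophenyl in place of 4-nitrophenyl on a carbon with a double bond to nitrogen. In words, 3-chlorophenyl takes the place of 4-nitrophenyl on a carbon with a double bond to nitrogen.

Within the data shown here, the one measured step at this place is a step that the two limits leave unreadable from compound 2 to compound 3, so it offers no size to carry over. Among the measured compounds shown here, the series so far holds no measured number, and no direction can be read from it. With all of compound 1, compound 2 and compound 3 at the same limit, no step beyond the scatter is expected in this assay.

The estimated step is a number no higher from compound 3 to compound 4 (the limit leaves the size open), and a further limit is the likeliest report. For compound 4 the expected value is 100000 nM, with an estimated range of 40000 nM to 150000 nM.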

Compound 4, concentration lethal to 50% of the cells: 45900 nM
For compound 4 the middle estimate is 2.2-fold (0.34 log units) above the measured one, within the range that was stated.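

In this assay, the place on the carbon with a double bond to nitrogen now yields a readable change: 3-chlorophenyl in place of 4-nitrophenyl gives an at least 2.1-fold lower number from compound 3 to compound 4 (0.33 log units; beyond the scatter). The comparison with the other nitro compound, chloro in place of nitro on an aromatic carbon, gives an at least 2.1-fold lower number from compound 2 to compound 4 (0.33 log units; beyond the scatter), so the result holds against both nitrophenyl compounds, and the whole group on the amide-type nitrogen gives an at least 2.1-fold lower number from compound 1 to compound 4 (0.33 log units; beyond the scatter). Each of these steps has a limit at its starting end, so compound 4 carries the only number in the series and the true size of each step stays open, while the step between the two nitrophenyl compounds cannot be read: the limit of > 100000 nM in this assay, at which 3 of the 4 values shown sit.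

The compounds shown leave open whether the change at this place depends on the chloro group itself or on the removal of nitro, which an unsubstituted phenyl, a bromo or a methoxy group on the same ring could separate. They also leave open whether a group with a chloro substituent at the 4-position of the phenyl ring would read as compound 4 does.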